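Replacing the Hexyl Chain of Compound 2 with Phenoxy

The source may hold more compounds than are shown below. What is called first, only, known or untested is meant among the compounds shown, and "the series" means these compounds.

Compound 2 `CCCCCCc1ccc(-c2c(C)[nH]c(=O)n2C2CCCCC2)cc1` gives 13700 nM in a functional assay on brain (Rattus norvegicus, strain Wistar) for inhibition; a lower number here means a stronger inhibitor, a higher number a weaker inhibitor; it stands together with compound 1 `CCCCCCc1ccc(-c2c(C)[nH]c(=O)n2C)cc1`, which gives 9000 nM, and the step of a 1.5-fold higher number from compound 1 to compound 2 (0.18 log units; within the scatter) lies within the scatter. Compound 3 `CCCCCCCCCCCCc1ccc(-c2c(C)[nH]c(=O)n2C2CCCCC2)cc1` gives only a limit of the assay, > 100000 nM. Among the measured compounds shown here, the step of an at least 7.2-fold higher number from compound 2 to compound 3 (0.86 log units; beyond the scatter) is the one measured change on the hexyl chain. Compound 4 `Cc1[nH]c(=O)n(C2CCCCC2)c1-c1ccc(Oc2ccccc2)cc1` differs from compound 2 by phenoxy in place of hexyl on an aromatic carbon. For the measured compounds named here, no measured step exchanges the chain for an aromatic group, so the lengthening seen in compound 3 offers only a loose guide. Compound 4 is therefore expected to show a step of a 1.1-fold higher number from compound 2 to compound 4 (0.04 log units; within the scatter), within the scatter. Compound 4 is estimated at 15000 nM, with a range from 5000 nM to 60000 nM.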

Compound 4, half-maximal inhibitory concentration: 7900 nM
Compound 4: middle estimate off by 1.9-fold (0.28 log units), on the high side; the range from low to high includes it.
By their numbers in this assay, from the lowest: compounds 4, 1 and 2 (each within the scatter of the next). At a limit, above all of these: compound 3.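

In this assay, phenoxy in place of the hexyl chain gives a 1.7-fold lower number from compound 2 to compound 4 (0.24 log units; within the scatter), so this aromatic carbon accepts an aromatic ring joined through oxygen as readily as the hexyl chain. The earlier compounds had shown only a chain at this position. The longer chain of compound 3 reached a limit of the assay, not a number: the limit of > 100000 nM in this assay, at which 1 of the 4 values shown sits.

On these data alone, what stays open is whether the oxygen of phenoxy matters, which a benzyl or plain phenyl group here would test. An amine or a carboxylic acid on the outer ring also remains unexplored in the compounds shown.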